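Changing the Sulfonyl Aryl Group: What Comes Next?

A few compounds are considered here, and "the series" means these few. Any claim that something is new, unique, unknown or untested is made for them only; others in the source may bear on it.

Measured so far in a functional assay on RS4-11 cells (Homo sapiens) for inhibition, read by CCK-8 assay, with a stated time of 48 h, tested at 20 uM; on this read-out lower numbers stand for less inhibition of growth and higher numbers for more inhibition of growth at the one concentration tested
- compound 1 `COc1ccc(S(=O)(=O)Oc2ccccc2/C=C(\C#N)C(=O)Nc2nnc(Cc3ccc(F)cc3)s2)cc1` gives 76%
- compound 2 `N#C/C(=C\c1ccccc1OS(=O)(=O)c1ccccc1[N+](=O)[O-])C(=O)Nc1nnc(Cc2ccc(F)cc2)s1` gives 61%

Compound 2 holds the lower of these two numbers, and the gap to compound 1 lies beyond the usual scatter. Compound 3 `N#C/C(=C\c1ccccc1OS(=O)(=O)c1ccc(Cl)cc1)C(=O)Nc1nnc(Cc2ccc(F)cc2)s1` has not yet been measured. On a sulfonyl sulfur, it carries 4-chlorophenyl in place of 2-nitrophenyl (4-chlorophenyl in place of 2-nitrophenyl on a sulfonyl sulfur).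

Going by the values given here, one measured step bears on this change, at the same sulfur: a number 15 percentage points lower from compound 1 to compound 2 (beyond the scatter). This modest drop came with 2-nitrophenyl replacing 4-methoxyphenyl. Among the compounds with values here, no measured compound carries 4-chlorophenyl, so this single step is thin evidence. Still, a partial recovery toward compound 1 seems likely, a rise somewhat smaller than that drop. The expected change is a number 11 percentage points higher from compound 2 to compound 3 (beyond the scatter). In this assay, compound 3 is estimated at 72%, with an expected range of 57% to 87%.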

Compound 3, percent growth inhibition at one concentration: 68%
Compound 3: middle estimate off by 4 percentage points, on the high side, within the range that was stated.
By their numbers in this assay, from the lowest: compounds 2, 3 and 1 (each within the scatter of the next, the first and the last beyond it).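

In this assay, 4-chlorophenyl on the sulfonyl sulfur cannot be told apart from either earlier group: the result is a number 7 percentage points higher from compound 2 to compound 3 (within the scatter) and a number 8 percentage points lower from compound 1 to compound 3 (within the scatter). Chloro in place of methoxy on the aromatic carbon therefore makes no clear difference here, and neither does 4-chlorophenyl in place of 2-nitrophenyl, so the only gap beyond the scatter at this sulfur remains the one between the 4-methoxyphenyl of compound 1 and the 2-nitrophenyl of compound 2. Nothing shown here explains how these aryl groups compare.

Still open, on these data alone, is how a phenyl ring carrying an amine or a carboxylic acid would compare at this sulfur, or a simple methyl group in place of the ring. A reading at one concentration also leaves open how these compounds would compare across a range of concentrations.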